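Alkyne in Place of Alkene on the Carbonyl Carbon

The source may hold more compounds than are shown below. What is called first, only, known or untested is meant among the compounds shown, and "the series" means these compounds.

Compound 1, `COc1ccc(N(CC(=O)NCCC[Se]c2ccccc2)C(=O)c2ccccc2)cc1`, in a functional assay on MCF7 cells (Homo sapiens) for cytotoxicity, read by MTT assay, with a stated time of 24 h (on this read-out lower numbers stand for stronger inhibition and higher numbers for weaker inhibition), gives >= 100000 nM.
Compound 2, `COc1ccc(N(CC(=O)NCCC[Se]c2ccccc2)C(=O)/C=C/c2ccccc2)cc1`, in this assay gives >= 100000 nM.

The value of compound 1 is a limit of the assay and not a number. The value of compound 2 is likewise only a limit. The step that the two limits leave unreadable from compound 1 to compound 2 therefore cannot be read; both values sit at the limit of >= 100000 nM in this assay, at which 2 of the 2 values shown sit, so compound 2 stands at that same limit, with nothing to rank it against compound 1.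

Compound 3, `COc1ccc(N(CC(=O)NCCC[Se]c2ccccc2)C(=O)C#Cc2ccccc2)cc1`, differs from compound 2 in one place: 2-phenylethynyl in place of 2-phenylethenyl on a carbonyl carbon. The only measured step concerns the same carbonyl substituent and is of unreadable size, so no change beyond the scatter can be argued for in this assay from the data shown. Compound 3 is expected to give about 100000 nM in this assay, with a range from 30000 nM to 300000 nM. The expected step is a number no higher from compound 2 to compound 3 (the limit leaves the size open), most likely ending once more at a limit rather than a number.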

Compound 3, half-maximal inhibitory concentration: >= 100000 nM
Compound 3 ended at the assay's limit; the forecaster's own chance of this, stated with the estimate: 75%; the middle value lies on the limit itself.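

No step among compound 1, compound 2 and compound 3 can be read, since each value is a limit of the assay and not a number: the limit of >= 100000 nM in this assay, at which 3 of the 3 values shown sit.

The compounds shown leave open how compound 1, compound 2 and compound 3 rank against one another in this assay, and whether the group on the carbonyl carbon matters there at all.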